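The source may report more compounds than this note shows. Statements on the series, on what has been measured and on what is new or still open speak of the compounds shown alone.

Compound 2 `Fc1ccccc1Cn1nc(C2=NCCN2)c2cccnc21` was tested in a functional assay (aorta) with Oryctolagus cuniculus as the target (a lower number here means a stronger inhibitor, a higher number a weaker inhibitor), where compound 2 gives 3200 nM; this is the only number shown for it, and one further entry gives no single number. Compound 1 `OCc1ccc(-c2nn(Cc3ccccc3F)c3ccccc23)o1` gives 4900 nM; 4900 nM (2 entries) in this assay. Compound 3 `Cc1cc(N)nc(-c2nn(Cc3ccccc3F)c3ncccc23)n1` differs from compound 2 in one place: a group of 8 heavy atoms (5 carbon, 3 nitrogen; one six-membered aromatic ring with 2 hetero atoms) in place of a group of 5 heavy atoms (3 carbon, 2 nitrogen; one five-membered non-aromatic ring with 2 hetero atoms), on an aromatic carbon. Going by the values given here, no step between two measured compounds follows this change, so its effect is not known from these data; the expected step of a 1.1-fold lower number from compound 2 to compound 3 (0.03 log units; within the scatter) is none beyond the usual scatter. Compound 3 is therefore estimated at 3000 nM, most likely between 700 nM and 13000 nM.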

Compound 3, half-maximal inhibitory concentration: 536000 nM
Compound 3: the middle estimate sits 180-fold (2.25 log units) below what was measured; measured number above the stated range.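

In this assay, this aromatic carbon of the five-membered aromatic ring is sensitive to what it carries: putting the 4-amino-6-methylpyrimidin-2-yl group in place of the five-membered non-aromatic ring brings a 170-fold higher number from compound 2 to compound 3 (2.22 log units; beyond the scatter) and so a much weaker inhibitor. The earlier compounds shown here gave no sign that one replacement here could cost so much. Nothing available explains this loss.

Whether the amino group, the methyl group or the six-membered aromatic ring itself accounts for the loss stays open. A plain pyrimidin-2-yl group on this carbon would help separate these.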